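A few compounds are considered here, and "the series" means these few. Any claim that something is new, unique, unknown or untested is made for them only; others in the source may bear on it.

Three compounds share one core and differ only in the group attached to one end. In a functional assay on HEK293 cells for agonist activity at Bombesin receptor subtype-3 (Homo sapiens), read by luminescence and calcium flux, with a stated time of 10 min (a higher number here means that more compound is needed for the effect, a lower number that less compound is needed), compound 1 `CCC(C)(C)Cc1c[nH]c(CCc2ccc(-c3cccc(C)n3)cc2)n1` gives 105 nM; compound 2 `CCC(C)(C)Cc1c[nH]c(CCc2ccc(-c3cccc(C#N)n3)cc2)n1` gives 193 nM; and compound 3 `c1ccc(-c2ccc(CCc3nc(CC4CCCC4)c[nH]3)cc2)nc1` gives 425 nM. Compound 2 stands second highest of these three numbers: the measured step of a 1.8-fold higher number from compound 1 to compound 2 (0.26 log units; within the scatter) lies within the scatter, while its gap to compound 3 lies beyond it.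

Compound 4 `CCC(C)(C)Cc1c[nH]c(CCc2ccc(-c3cccnc3C(=O)O)cc2)n1` is unmeasured. It changes compound 2 by 2-carboxypyridin-3-yl in place of 6-cyanopyridin-2-yl on an aromatic carbon. Among the measured compounds shown here, the only measured step, from compound 1 to compound 2, swaps one small substituent on the same pyridine for another and stays within the scatter. For the measured compounds named here, no measured step exchanges the whole pyridine attachment or brings in a carboxylic acid, so the expectation rests on little. For compound 4 the step of a 3.1-fold higher number from compound 2 to compound 4 (0.49 log units; beyond the scatter) is expected, towards a higher number, beyond the scatter but with wide uncertainty. In this assay compound 4 is therefore estimated at 600 nM, within a range of 150 nM to 3000 nM.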

Compound 4, half-maximal effective concentration: 1260 nM
Estimate against measurement, compound 4: 2.1-fold (0.32 log units) below; the range from low to high includes it.
By their numbers in this assay, from the lowest: compounds 1 and 2 (each within the scatter of the next); then compound 3; then compound 4.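

This position is not indifferent to what it carries: in this assay the change to 2-carboxypyridin-3-yl gives a 6.5-fold higher number from compound 2 to compound 4 (0.81 log units; beyond the scatter) and a 12-fold higher number from compound 1 to compound 4 (1.08 log units; beyond the scatter) whereas the swap of methyl for cyano on the pyridine stayed within the scatter. Among the compounds shown here, a change at this end of the molecule can therefore mean that clearly more compound is needed for the effect, and compound 4 is the only example of this so far. No measurement at hand explains why the number rises.

Compound 4 changes both how the pyridine is attached and which group it carries, and the compounds shown do not separate these two changes. On these data alone, whether a 6-carboxypyridin-2-yl group, or a methyl ester in place of the carboxylic acid of compound 4, would give a similar number stays open.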